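Chloro gives way to 3-hydroxypropyl on a stable compound

The compounds below may be only part of what the source reports. "The series", "measured", "known", "first", "only" and "open" are said of these compounds alone.

In an ADME assay on microsomes from liver (Canis lupus familiaris) for metabolic stability, with a stated time of 10 min (a lower number here means that less of the compound is left, a higher number that more of the compound is left), compound 1 (`FC(F)(F)c1ccccc1-c1ccc2[nH]c(C3=NC4(CCCCC4)CO3)nc2c1`) gives 32% while compound 2 (`FC(F)(F)c1ccccc1-c1cc(Cl)c2[nH]c(C3=NOC4(CCCCC4)C3)nc2c1`) gives 100% and so holds the higher of the two numbers, with a gap well beyond the scatter. These two compounds differ in more than one place, so their gap cannot be tied to any single change.

Compound 3 (`OCCCc1cc(-c2ccccc2C(F)(F)F)cc2nc(C3=NOC4(CCCCC4)C3)[nH]c12`) differs from compound 2 in one place. 3-hydroxypropyl stands in place of chloro on an aromatic carbon, meta to a 2-(trifluoromethyl)phenyl group (3-hydroxypropyl in place of chloro on an aromatic carbon). Among the measured compounds shown here, no measured pair shows what this change does, so the expectation rests on little. Compound 2 at 100% leaves no room for a rise, and compound 1 at 32% shows that much lower numbers do occur among these compounds. The expected step in this assay is a fall beyond the scatter, estimated as a number 30 percentage points lower from compound 2 to compound 3 (beyond the scatter) with considerable uncertainty. For compound 3 the estimated value is 70% with an expected range from 45% to 95% until it is measured.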

Compound 3, percent of the compound remaining: 12%
Compound 3: the middle estimate sits 58 percentage points above what was measured, and the stated range ends above it.
By their numbers in this assay, from the lowest: compound 3; then compound 1; then compound 2.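

In this assay the exchange of chloro for 3-hydroxypropyl gives a number 88 percentage points lower from compound 2 to compound 3 (beyond the scatter) on its own. Among the compounds shown here, this makes the aromatic carbon ortho to a fused ring and meta to a 2-(trifluoromethyl)phenyl group the first place where a single change can be tied to a shift in the number, something the gap between the earlier compounds could not offer, since they differ in more than one place. No measurement shown here speaks to why the number falls so far, so the step stands as an observation on this one pair.

Whether the fall goes with the carbon chain itself or with the hydroxyl at its end stays open, since 3-hydroxypropyl is the only replacement for chloro shown at this position. A plain propyl chain on the same aromatic carbon would separate those two readings, and a methoxy group or an amine at the end of the chain would show whether the hydroxyl can be exchanged without the same loss.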